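Aryl Swap on a Shared Core: Compound 2 to Compound 3

This account rests on a few compounds, and the source may have more. Where it says the series, first, only, none or still open, it means among the compounds named here.

Two compounds have been measured in a functional assay on HCT-15 cells (Homo sapiens) for cytotoxicity, in the presence of a further agent that is not named here; on this read-out higher numbers stand for weaker inhibition and lower numbers for stronger inhibition:

compound 1, `Clc1ccc(-c2cc(-c3cccnc3)nc(-c3cccs3)c2)o1`, gives 1240 nM
compound 2, `Clc1ccc(-c2cc(-c3cccs3)nc(-c3ccccc3Cl)c2)o1`, gives 6190 nM

Compound 2 stands at the higher of the two numbers; its nearest neighbour is compound 1, and the step of a 5.0-fold higher number from compound 1 to compound 2 (0.70 log units; beyond the scatter) lies beyond the scatter. Compound 3, `Cc1ccc(-c2cc(-c3ccc(Cl)o3)cc(-c3cccs3)n2)cc1`, differs from compound 2 by 4-methylphenyl in place of 2-chlorophenyl on an aromatic carbon. Among the compounds with values here, no measured step covers this exact exchange. Within the data shown here, the only step at the same position, a 5.0-fold higher number from compound 1 to compound 2 (0.70 log units; beyond the scatter), shows that replacing the group on this aromatic carbon can move the read-out by a modest amount in either direction. For compound 3 the expected value in this assay is therefore 4000 nM, with a range from 1500 nM to 12000 nM. That estimate corresponds to an expected step of a 1.5-fold lower number from compound 2 to compound 3 (0.19 log units; within the scatter), within the range where neither a clear gain nor a clear loss can be claimed.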

Compound 3, half-maximal inhibitory concentration: 9890 nM
Compound 3: middle estimate off by 2.5-fold (0.39 log units), on the low side, and the stated range covers the measured number.
By their numbers in this assay, from the lowest: compound 1; then compounds 2 and 3 (each within the scatter of the next).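

In this assay the exchange of 2-chlorophenyl for 4-methylphenyl gives a 1.6-fold higher number from compound 2 to compound 3 (0.20 log units; within the scatter) and so separates these two substituted phenyl groups at this position by no more than the scatter, even though the chlorine is gone and a methyl stands at another place on the ring. The step from pyridin-3-yl to 4-methylphenyl, an 8.0-fold higher number from compound 1 to compound 3 (0.90 log units; beyond the scatter) in the same assay, is beyond the scatter, so among these three compounds both phenyl groups stand apart from pyridin-3-yl, which gives the lowest number. No measurement shown here explains either step.

The compounds shown leave open how unsubstituted phenyl, pyridin-4-yl or a phenyl bearing an amine or a carboxylic acid would read at this position. They also cannot separate the effect of swapping chlorine for methyl from that of moving the substituent around the ring.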